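This account rests on a few compounds, and the source may have more. Where it says the series, first, only, none or still open, it means among the compounds named here.

Series around the shared core of compound 1 `Cc1cc(O)c(C2=NN(c3ccc(S(N)(=O)=O)cc3)C(c3ccccc3O)C2)cc1Cl`. In a functional assay on UACC-257 cells (Homo sapiens) for antiproliferative activity, with a stated time of 48 h (on this read-out higher numbers stand for lower toxicity in this test and lower numbers for higher toxicity in this test), compound 1 gives 59000 nM. Compound 2 `Cc1cc(O)c(C2=NN(c3ccc(S(N)(=O)=O)cc3)C(c3ccccc3Cl)C2)cc1Cl` reaches only the limit of this assay, > 100000 nM. Compound 3 `Cc1cc(O)c(C2=NN(c3ccc(S(N)(=O)=O)cc3)C(/C=C/c3ccccc3)C2)cc1Cl` likewise stops at the limit of this assay, > 100000 nM. Compound 3 thus stands at the upper edge of the numbers shown (the limit of > 100000 nM in this assay, at which 2 of the 3 values shown sit). Compound 4 `COc1ccc(C2CC(c3cc(Cl)c(C)cc3O)=NN2c2ccc(S(N)(=O)=O)cc2)cc1OC` carries the change (3,4-dimethoxyphenyl in place of 2-phenylethenyl on a saturated ring carbon). The measured steps that bear on it are an at least 1.6-fold higher number from compound 1 to compound 3 (0.22 log units; that floor lies within the scatter) and a step that the two limits leave unreadable from compound 2 to compound 3. Neither resolves a direction beyond the scatter, so no step beyond the scatter is expected in this assay and a further limit is likely. Compound 4 is expected at 100000 nM, within 40000 nM to 300000 nM. The expected step is a number no higher from compound 3 to compound 4 (the limit leaves the size open).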

Compound 4, concentration lethal to 50% of the cells: > 100000 nM
Compound 4: only a limit was reported; the forecaster's own chance of this, stated with the estimate: 70%; the middle value lies on the limit itself.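

At this saturated ring carbon, 3,4-dimethoxyphenyl brings 2 hydrogen-bond acceptors where 2-phenylethenyl has none, yet compound 4 also gives only a limit in this assay, and this limit is now the commonest result in the series: the limit of > 100000 nM in this assay, at which 3 of the 4 values shown sit. Among these compounds, the only readable new step is an at least 1.6-fold higher number from compound 1 to compound 4 (0.22 log units; that floor lies within the scatter) and gives no direction beyond the scatter. The steps from compound 2 and compound 3 to compound 4 cannot be read, since each joins two limits.

On these data alone, whether an amine or a carboxylic acid at this ring carbon would give a number short of the limit remains open.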